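Capping the hydroxyl of compound 1 as a methyl ether

A few compounds are considered here, and "the series" means these few. Any claim that something is new, unique, unknown or untested is made for them only; others in the source may bear on it.

Going by these compounds, compound 1 `COc1cc(C(c2ccc(O)c(OC)c2)[C@@H](C)[C@@H](C)CO)ccc1O` sits at the floor of the series: in a functional assay on HL-60 cells (Homo sapiens) for cytotoxicity, read by WST assay, with a stated time of 48 h (on this read-out lower numbers stand for stronger inhibition and higher numbers for weaker inhibition), compound 1 gives only a limit, > 100000 nM, so its true value remains unknown (the limit of > 100000 nM in this assay, at which 1 of the 3 values shown sits). Compound 2 `COC[C@@H](C(C)C)C(c1ccc(O)c(OC)c1)c1ccc(O)c(OC)c1` gives 54000 nM in this assay, and compound 3 `COc1cc(C(c2ccc(O)c(OC)c2)[C@@H](C)[C@H](C)CF)ccc1O` gives 32000 nM. The step of an at least 1.8-fold lower number from compound 1 to compound 2 (0.26 log units; that floor lies within the scatter) is at its floor within scatter, while an at least 3.1-fold lower number from compound 1 to compound 3 (0.49 log units; beyond the scatter) is at least modest; the pair a 1.7-fold lower number from compound 2 to compound 3 (0.23 log units; within the scatter) lies within scatter.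

Compound 4 `COC[C@@H](C)[C@H](C)C(c1ccc(O)c(OC)c1)c1ccc(O)c(OC)c1` differs from compound 1 as follows: 1-(methoxymethyl)ethyl in place of 1-(hydroxymethyl)ethyl on a saturated chain carbon bound to two saturated chain carbons. The step from compound 1 to compound 2 already shows what a methoxymethyl group can do alongside a change in the neighbouring branch, and the step from compound 1 to compound 3 shows that removing the hydroxyl donor lowers the number. Compound 4 is therefore expected to show a step of an at least 2.0-fold lower number from compound 1 to compound 4 (0.30 log units; that floor lies within the scatter), landing near compound 2, though a value at the limit remains possible. Compound 4 is estimated at 50000 nM, between 20000 nM and 150000 nM.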

Compound 4, half-maximal inhibitory concentration: 73000 nM
Compound 4: the middle estimate sits 1.5-fold (0.16 log units) below what was measured; low and high end bracket the measured number.
By their numbers in this assay, from the lowest: compounds 3, 2 and 4 (each within the scatter of the next, the first and the last beyond it). At a limit, above all of these: compound 1.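

In this assay, the methyl ether alone, on a saturated chain carbon bound to two saturated chain carbons, gives an at least 1.3-fold lower number from compound 1 to compound 4 (0.13 log units; that floor lies within the scatter). Compound 1 gives only a limit, so the true size of this step cannot be read: the limit of > 100000 nM in this assay, at which 1 of the 4 values shown sits. With the cap in place, the choice of group at the chain end counts, as methoxy in place of fluoro gives a 2.3-fold higher number from compound 3 to compound 4 (0.36 log units; beyond the scatter), whereas the change of branch between the two methyl ethers gives a 1.4-fold higher number from compound 2 to compound 4 (0.13 log units; within the scatter), which sets neither of them ahead of the other.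

The compounds shown leave open how an amine or a carboxylic acid would read at this chain end. They also leave open whether an ethoxymethyl group, with its longer chain, would read like the methoxymethyl group.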